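A few compounds are considered here, and "the series" means these few. Any claim that something is new, unique, unknown or untested is made for them only; others in the source may bear on it.

Measured so far in this study:
compound 1, `CCOc1ccc2sc(S(C)(=O)=O)nc2c1S(=O)(=O)NC(C)(C)C`: 38600 nM
compound 2, `CCOc1ccc2sc(S(C)(=O)=O)nc2c1S(=O)(=O)Nc1ccc([N+](=O)[O-])cc1`: 40800 nM

Both were read in a functional assay on HeLa cells (Homo sapiens) for inhibition, read by sulforhodamine B assay, with a stated time of 48 h; a higher number here means a weaker inhibitor of growth, a lower number a stronger inhibitor of growth. Compound 1 holds the lowest of the two numbers there, and its nearest neighbour stands at a 1.1-fold higher number from compound 1 to compound 2 (0.02 log units; within the scatter), a change of 4-nitrophenyl in place of tert-butyl on the sulfonamide nitrogen, so the two measured compounds are not told apart by this assay.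

Compound 3, `CCOc1ccc2sc(S(C)(=O)=O)nc2c1N`, has not yet been measured. It differs from compound 1 in one place: amino in place of (tert-butyl)sulfamoyl on an aromatic carbon. Among the compounds with values here, the only measured step, from compound 1 to compound 2, keeps the sulfamoyl group and alters just the substituent on its nitrogen, and that step stayed within the scatter. Within the data shown here, it therefore says little about taking the whole sulfamoyl group away and leaving an amino group in its place; no measured pair tests that change. With nothing to point either way, the step in this assay is expected to be small or none beyond the scatter, with a wide uncertainty in both directions.

Compound 3 is thus expected to give about 45000 nM in this assay, within a range from 15000 nM to 150000 nM. That estimate corresponds to an expected step of a 1.2-fold higher number from compound 1 to compound 3 (0.07 log units; within the scatter).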

Compound 3, concentration for total growth inhibition: 74300 nM
Compound 3: the middle estimate sits 1.7-fold (0.22 log units) below what was measured; the range from low to high includes it.
By their numbers in this assay, from the lowest: compounds 1, 2 and 3 (each within the scatter of the next).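

At this aromatic carbon, ortho to an ethoxy group, this assay does not tell apart the (tert-butyl)sulfamoyl group, with its 8 heavy atoms, and an amino group, with 1 heavy atom (a 1.9-fold higher number from compound 1 to compound 3 (0.28 log units; within the scatter)). Earlier, only the substituent on the sulfonamide nitrogen had been changed (a 1.1-fold higher number from compound 1 to compound 2 (0.02 log units; within the scatter)), so that step left open whether the sulfamoyl group itself could be replaced; the new step shows that, in this one replacement on the core of compound 1, removing it gives no difference beyond the scatter. No supporting measurement bears on this result, and the data offer no explanation for it.

The compounds shown leave open whether another group on this same carbon, such as a carboxylic acid, an acetamide or a longer chain on the amino nitrogen, would give a step beyond the scatter in this assay. They also leave open how that assay would respond if the neighbouring ethoxy group gave way to a methoxy group or a longer alkoxy chain.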